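The source may report more compounds than this note shows. Statements on the series, on what has been measured and on what is new or still open speak of the compounds shown alone.

Compound 1 `N[C@H]1CC[C@H](Nc2c(C(=O)NCc3ccc(F)cc3)nc(N3CCCCS3(=O)=O)c3cccnc23)CC1` has been tested in a functional assay on HCT-116 cells (Homo sapiens) for cytotoxicity, read by MTT assay, with a stated time of 72 h (a higher number here means a weaker inhibitor, a lower number a stronger inhibitor), where compound 1 gives only a limit, > 10000 nM, rather than a number, a situation described by the limit of > 10000 nM in this assay, at which 1 of the 2 values shown sits. A second compound, compound 2 `COc1cccc(CNC(=O)c2nc(Br)c3cccnc3c2N[C@H]2CC[C@H](N)CC2)c1`, also carries a bromine on the shared core, and in this assay compound 2 gives 6000 nM. Compound 3 `N[C@H]1CC[C@H](Nc2c(C(=O)NCc3ccc(F)cc3)nc(Br)c3cccnc23)CC1` has not yet been measured; it differs from compound 1 in one place: one bromine atom in place of a group of 8 heavy atoms (4 carbon, 1 nitrogen, 2 oxygen, 1 sulfur; one six-membered non-aromatic ring with 2 hetero atoms), on an aromatic carbon. Among the compounds with values here, no measured pair shows exactly this exchange, so the size of the step cannot be read off from the data and remains an expectation. Since compound 2, which likewise carries a bromine, reaches 6000 nM, compound 3 is expected to give about 5000 nM, within a range from 1500 nM to 15000 nM. This corresponds to an expected at least 2.0-fold lower number from compound 1 to compound 3 (0.30 log units; that floor lies within the scatter), in the direction of a stronger inhibitor, although that reading rests on a single comparison compound.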

Compound 3, half-maximal inhibitory concentration: 7000 nM
Beside the measured number, compound 3's estimate is 1.4-fold (0.15 log units) below it; the measured number falls inside the stated range.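

In this assay compound 1 gives > 10000 nM, which is a limit of the assay and not a number. Putting bromo in place of its six-membered non-aromatic ring with 2 hetero atoms, on the aromatic carbon next to the ring nitrogen, gives an at least 1.4-fold lower number from compound 1 to compound 3 (0.15 log units; that floor lies within the scatter), so this exchange yields only a floor within the scatter, and its true size cannot be read: the limit of > 10000 nM in this assay, at which 1 of the 3 values shown sits. With bromo at this position, 4-fluorophenyl in place of 3-methoxyphenyl gives a 1.2-fold higher number from compound 2 to compound 3 (0.07 log units; within the scatter), so these two groups cannot be told apart in this assay.

Going by these compounds, how an amine or a nitrile on this aromatic carbon would compare with bromo remains open. Also open, on these data alone, is whether a morpholine ring here would give a measurable number or another limit.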